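Pyridin-2-yl in place of thiophen-2-yl

A few compounds are considered here, and "the series" means these few. Any claim that something is new, unique, unknown or untested is made for them only; others in the source may bear on it.

Compound 1 `Oc1cccc(-c2cc(-c3ccccc3)cc(-c3cccc(O)c3)n2)c1` gives 16400 nM
Compound 2 `Oc1cccc(-c2cc(-c3ccccc3)nc(-c3cccs3)c2)c1` gives 18900 nM

In a functional assay on HL-60 cells (Homo sapiens) for cytotoxicity, read by ELISA, with a stated time of 2 days (a lower number here means a stronger inhibitor, a higher number a weaker inhibitor), compound 1 reads 16400 nM and compound 2 reads 18900 nM so the two numbers lie within the usual scatter of each other, and neither can be ranked over the other. Among the compounds with values here, these two compounds differ in more than one place, so they offer no single-change step to carry forward.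

Compound 3 `Oc1cccc(-c2cc(-c3ccccc3)nc(-c3ccccn3)c2)c1` has not yet been measured. The change pyridin-2-yl in place of thiophen-2-yl on an aromatic carbon puts pyridin-2-yl in place of thiophen-2-yl on an aromatic carbon, next to the ring nitrogen. Each group is one aromatic ring with 1 hetero atom, and the rest of compound 2 stays as it is. Within the data shown here, no measured pair shows this exchange, so the expectation rests only on compound 2 at 18900 nM and on the structural change itself. No shift beyond the scatter is expected in this assay and the estimate is a 1.3-fold lower number from compound 2 to compound 3 (0.10 log units; within the scatter) as the expected step. Compound 3 is expected to read 15000 nM (estimated range 6000 nM to 40000 nM).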

Compound 3, half-maximal inhibitory concentration: 15100 nM
Beside the measured number, compound 3's estimate is 1.0-fold (0.00 log units) below it, and the stated range covers the measured number.
By their numbers in this assay, from the lowest: compounds 3, 1 and 2 (each within the scatter of the next).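

In this assay, putting pyridin-2-yl in place of thiophen-2-yl on the aromatic carbon next to the ring nitrogen gives a 1.3-fold lower number from compound 2 to compound 3 (0.10 log units; within the scatter), the only single-change step among these compounds. At this place, then, a five-membered aromatic ring with 1 hetero atom and a six-membered aromatic ring with 1 hetero atom cannot be told apart by this read-out, even though the sulfur of one gives way to the nitrogen of the other and the ring gains a heavy atom. Nothing at hand accounts for the two groups reading alike.

From the compounds shown here alone, both groups are single aromatic rings, so it remains open whether this position would read the same with something of another kind on it, such as an amine, a carboxylic acid or a longer alkyl chain. It is also open how much the 3-hydroxyphenyl and phenyl groups contribute to the reading, as no step shown changes either of them alone.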